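The source may hold more compounds than are shown below. What is called first, only, known or untested is meant among the compounds shown, and "the series" means these compounds.

Three compounds share one core and differ only in the aryl group that ends a double-bonded chain, and all three were tested in an assay on isolated protein with Bile acid receptor (Homo sapiens) as the target; on this read-out higher numbers stand for an effect only at larger amounts of compound and lower numbers for an effect already at smaller amounts. Compound 1 `COC(=O)/C=C/c1cccc(N(Cc2ccc(/C=C/c3c(C)cc(C)cc3C)cc2)C(=O)C(C)C)c1` gives 149 nM in this assay. Compound 2 `COC(=O)/C=C/c1cccc(N(Cc2ccc(/C=C/c3ccccn3)cc2)C(=O)C(C)C)c1` gives 310 nM, and compound 3 `COC(=O)/C=C/c1cccc(N(Cc2ccc(/C=C/c3scnc3C)cc2)C(=O)C(C)C)c1` gives 228 nM. Compound 3 stands second highest of the three numbers, with compound 2 nearest and compound 1 furthest, and both gaps lie within the scatter, so no reliable ranking among the three emerges. The measured steps were a 2.1-fold higher number from compound 1 to compound 2 (0.32 log units; beyond the scatter), a 1.5-fold higher number from compound 1 to compound 3 (0.18 log units; within the scatter) and a 1.4-fold lower number from compound 2 to compound 3 (0.13 log units; within the scatter); only the first lies beyond the scatter, and each of them swaps one aryl group for another while keeping the double-bonded chain. Compound 4 `COC(=O)/C=C/c1cccc(N(Cc2ccc(-c3cccc(Cl)c3)cc2)C(=O)C(C)C)c1` goes further than that: 3-chlorophenyl in place of 2-(4-methyl-1,3-thiazol-5-yl)ethenyl on an aromatic carbon. Among the measured compounds shown here, no measured step removes the double-bonded chain itself, so the three aryl swaps bear on this change only loosely; they show that alterations at this end of the molecule have moved the number modestly at most. The step from compound 3 to compound 4 is therefore expected to be small and uncertain in direction, estimated at a 1.5-fold higher number from compound 3 to compound 4 (0.19 log units; within the scatter). Compound 4 is expected to give 350 nM in this assay, within a range from 120 nM to 1000 nM.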

Compound 4, half-maximal effective concentration: 77 nM
Beside the measured number, compound 4's estimate is 4.5-fold (0.66 log units) above it; the measured number lies below the stated range.
By their numbers in this assay, from the lowest: compounds 4, 1, 3 and 2 (each within the scatter of the next, the first and the last beyond it).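

In this assay, taking out the double-bonded chain and setting 3-chlorophenyl directly on the aromatic carbon does not cost activity: it gives a 3.0-fold lower number from compound 3 to compound 4 (0.47 log units; beyond the scatter) and a 4.0-fold lower number from compound 2 to compound 4 (0.60 log units; beyond the scatter) in this series, whereas the earlier aryl swaps all kept the chain and could not test whether it was needed. The same replacement gives a 1.9-fold lower number from compound 1 to compound 4 (0.29 log units; within the scatter) and so matches compound 1, which carries 2,4,6-trimethylphenyl, without any double bond outside the aromatic rings, showing that the chain is not required for a number in this range among these compounds. Nothing available explains these steps, and neither the loss of the double bond nor the chlorine can be assigned a cause.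

Compound 4 changes the link and the terminal group in one step, so the shares of the lost chain and the chlorine in the lower number stay unresolved. Going by these compounds, it also remains open what an unsubstituted phenyl, or a phenyl bearing a methoxy group or a carboxylic acid, would give on this aromatic carbon.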